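This account rests on a few compounds, and the source may have more. Where it says the series, first, only, none or still open, it means among the compounds named here.

Among the measured compounds shown here, compound 2 `O=C(O)c1ccccc1-c1ccc(CCc2ncc(Cc3ccc(Cl)cc3)[nH]2)cc1` holds the higher of the two numbers measured so far: in an in vitro functional assay on cells for agonist activity at Bombesin receptor subtype-3 (Mus musculus), read by luminescence and calcium flux (on this read-out lower numbers stand for an effect already at smaller amounts and higher numbers for an effect only at larger amounts of compound), compound 2 gives 102 nM. For the measured compounds named here, the only other measured compound, compound 1 `O=C(O)c1ccccc1-c1ccc(CCc2ncc(CC3CCCCC3)[nH]2)cc1`, gives 7.3 nM in this assay, and the sole measured step is a 14-fold higher number from compound 1 to compound 2 (1.15 log units; beyond the scatter). Compound 3 `O=C(O)c1ccccc1-c1ccc(CCc2ncc(Cc3cccc(F)c3)[nH]2)cc1` is not yet measured; it differs from compound 2 in that (3-fluorophenyl in place of 4-chlorophenyl on a saturated chain carbon bound to an aromatic carbon). Going by the values given here, no measured step exchanges one aromatic group for another at this position, so the known step bears on it only distantly: it shows that the group on this saturated chain carbon can move the number a long way, but offers no direction for swapping one halogenated phenyl for another. A step of modest size, in either direction or none beyond the scatter, is therefore expected, a 1.0-fold lower number from compound 2 to compound 3 (0.01 log units; within the scatter). Compound 3 is estimated at 100 nM, with a range from 30 nM to 350 nM.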

Compound 3, half-maximal effective concentration: 7.9 nM
The estimate for compound 3 lay 13-fold (1.10 log units) above the measured number; the measured number lies below the stated range.
By their numbers in this assay, from the lowest: compounds 1 and 3 (each within the scatter of the next); then compound 2.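

In this assay, the change from 4-chlorobenzyl to 3-fluorobenzyl gives a 13-fold lower number from compound 2 to compound 3 (1.11 log units; beyond the scatter), so exchanging one halogenated phenyl for another on this saturated chain carbon can by itself produce a large step. Among the compounds shown here, the earlier compounds did not show this: their only step replaced cyclohexyl with 4-chlorophenyl, and it could have been read as a penalty for the aromatic ring. Compound 3 rules out that reading, since the change to 3-fluorophenyl gives a 1.1-fold higher number from compound 1 to compound 3 (0.03 log units; within the scatter), which stays within the scatter.

This exchange alters both the halogen and its place on the ring at once, so 3-chlorophenyl and 4-fluorophenyl would be needed to separate the two. The data shown offer no explanation for the size of the step from 4-chlorophenyl to 3-fluorophenyl.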